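The compounds below may be only part of what the source reports. "The series", "measured", "known", "first", "only" and "open" are said of these compounds alone.

The measured compounds:
compound 1, `O=c1c(SC(=S)N2CCCCC2)coc2ccccc12`, 17400 nM
compound 2, `O=c1cc(CSC(=S)N2CCCC2)oc2ccccc12`, > 30000 nM
compound 3, `O=c1cc(CSC(=S)N2CCCC2)oc2cc(Cl)ccc12`, > 25000 nM

Within the data shown here, in a functional assay on MDA-MB-435S cells (Homo sapiens) for antiproliferative activity, read by MTT assay, with a stated time of 72 h (a higher number here means a weaker inhibitor, a lower number a stronger inhibitor), compound 1 gives 17400 nM, the only plain number among the three. For compound 2 this assay reports only a limit, > 30000 nM. For compound 3 it likewise reports only a limit, > 25000 nM. Compound 1 and compound 2 are built from the same atoms joined differently; the difference between the two cores is not broken down here.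

Compound 3 differs from compound 2 by chloro in place of hydrogen on an aromatic carbon, and the resulting step, a step that the two limits leave unreadable from compound 2 to compound 3, cannot be sized, since both ends are limits, the limit of > 30000 nM in this assay, at which 1 of the 3 values shown sits, and (the limit of > 25000 nM in this assay, at which 1 of the 3 values shown sits).

Compound 4, `O=c1c(SC(=S)N2CCCCC2)coc2ccc(Cl)cc12`, differs from compound 1 by chloro in place of hydrogen on an aromatic carbon, the same change made at the same kind of place. Among the measured compounds shown here, with the one measured example of this change unreadable, the expectation rests on compound 1 at 17400 nM and on the small size of the change. The step is expected to be about a 1.2-fold lower number from compound 1 to compound 4 (0.06 log units; within the scatter). Compound 4 is therefore estimated at 15000 nM, most likely between 5000 nM and 40000 nM.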

Compound 4, half-maximal inhibitory concentration: 13300 nM
Beside the measured number, compound 4's estimate is 1.1-fold (0.05 log units) above it; measured number inside the range.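

In this assay, chloro in place of hydrogen on an aromatic carbon gives a 1.3-fold lower number from compound 1 to compound 4 (0.12 log units; within the scatter), so on the core of compound 1 this change has no effect that can be told apart from the usual scatter of repeated measurements. Compound 2 gives only a limit of the assay, not a plain number: the limit of > 30000 nM in this assay, at which 1 of the 4 values shown sits. Compound 3 also gives only a limit, so the matching step on the other core cannot be read, and nothing here shows whether the result on the core of compound 1 carries over to that core: the limit of > 25000 nM in this assay, at which 1 of the 4 values shown sits.

The compounds shown leave open whether a different group at this place on the core of compound 1, such as a methoxy group or an amine, would move the number beyond the scatter. They also leave open whether any change to the core of compound 2 would give a plain number in this assay.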